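Iodo for bromo on a strongly active fluoro compound

A few compounds are considered here, and "the series" means these few. Any claim that something is new, unique, unknown or untested is made for them only; others in the source may bear on it.

Compound 2 `NC(=O)NC(=O)c1cc(NC(=O)CBr)ccc1F` carries fluoro on an aromatic carbon and bromo on a saturated chain carbon. In a functional assay on CCRF-CEM cells (Homo sapiens) for antiproliferative activity, read by trypan blue exclusion, with a stated time of 72 h (a higher number here means a weaker inhibitor, a lower number a stronger inhibitor), compound 2 gives < 10 nM, which is a limit of the assay and not a number. Compound 1 `Cc1ccc(NC(=O)CBr)cc1C(=O)NC(N)=O`, with methyl on that aromatic carbon, gives 4760 nM, and compound 3 `NC(=O)NC(=O)c1cc(NC(=O)CBr)ccc1Br`, with bromo there, gives 1160 nM. Compound 2 thus stands clearly ahead of both, as an at least 470-fold lower number from compound 1 to compound 2 (2.67 log units; beyond the scatter) and an at least 110-fold higher number from compound 2 to compound 3 (2.06 log units; beyond the scatter) show.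

Compound 4 `NC(=O)NC(=O)c1cc(NC(=O)CI)ccc1F` alters a different spot: iodo in place of bromo on a saturated chain carbon bound to a carbonyl carbon. Within the data shown here, none of the measured steps touches that carbon. All three change the aromatic carbon, and they range from large to modest, the modest one being a 4.1-fold lower number from compound 1 to compound 3 (0.61 log units; beyond the scatter). They therefore offer no direct guide, and no step beyond the scatter is expected in this assay, in either direction. Among the measured compounds shown here, the only anchor is compound 2, whose entry is the limit < 10 nM. The estimated change is a number no lower from compound 2 to compound 4 (the limit leaves the size open). For compound 4 the expected value is 10 nM, with an estimated range of 3 nM to 50 nM.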

Compound 4, half-maximal inhibitory concentration: < 10 nM
Compound 4 ended at the assay's limit; the forecaster's own chance of this, stated with the estimate: 45%; the middle value sits exactly at the limit.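

No step can be read from compound 2 to compound 4, since the entries for both compounds are limits and not numbers: the limit of < 10 nM in this assay, at which 2 of the 4 values shown sit.

The compounds shown leave open whether iodo in place of bromo on a saturated chain carbon bound to a carbonyl carbon changes the antiproliferative activity at all, and in which direction.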